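A methyl added to the core of compound 2

The source may hold more compounds than are shown below. What is called first, only, known or untested is meant among the compounds shown, and "the series" means these compounds.

Compound 2 `CSc1nc2ccc(Br)cn2c(=N)c1S(=O)(=O)c1ccccc1` gives 56 nM in an assay on HeLa cells for displacement of a labelled ligand from 5-hydroxytryptamine receptor 6 (Homo sapiens) (on this read-out higher numbers stand for weaker inhibition and lower numbers for stronger inhibition), the second highest of the three numbers shown. Its closest neighbour is compound 1 `CSc1nc2ccc(Cl)cn2c(=N)c1S(=O)(=O)c1ccccc1` with 28 nM; the step of a 2.0-fold higher number from compound 1 to compound 2 (0.30 log units; within the scatter) lies within the scatter. Compound 3 `COC(=O)c1ccc2nc(SC)c(S(=O)(=O)c3ccccc3)c(=N)n2c1` gives 470 nM, and the step of an 8.4-fold higher number from compound 2 to compound 3 (0.92 log units; beyond the scatter) is beyond the scatter, as is the step of a 17-fold higher number from compound 1 to compound 3 (1.22 log units; beyond the scatter).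

Compound 4 `CSc1nc2c(C)cc(Br)cn2c(=N)c1S(=O)(=O)c1ccccc1` differs from compound 2 by methyl in place of hydrogen on an aromatic carbon. None of the three measured steps touches this position; all of them swap the group at the place where chloro, bromo or methoxycarbonyl sits, so they offer no direct guide. For the measured compounds named here, they show only that the shared core keeps its activity when a small group is swapped for another small group, and loses it when a larger methoxycarbonyl enters. A methyl is a small addition at an untested spot, so no step beyond the scatter is expected.

Compound 4 is therefore expected to give about 56 nM in this assay, within 20 nM to 160 nM, corresponding to an expected step of no change at the digits printed from compound 2 to compound 4 (within the scatter).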

Compound 4, half-maximal inhibitory concentration: 12 nM
Compound 4: middle estimate off by 4.7-fold (0.67 log units), on the high side; measured number below the stated range.
By their numbers in this assay, from the lowest: compound 4; then compounds 1 and 2 (each within the scatter of the next); then compound 3.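

In this assay, adding the methyl gives a 4.7-fold lower number from compound 2 to compound 4 (0.67 log units; beyond the scatter) and so moves the number towards stronger inhibition, by more than the usual scatter. The earlier steps shown here only swapped the group at the place held by chloro, bromo or methoxycarbonyl, whereas this one shows that a second place on the shared core also affects the number: the aromatic carbon ortho to a fused ring and meta to the bromo group. Nothing measured here accounts for the change.

The compounds shown leave open whether an ethyl, a methoxy or an amine on this carbon would give a similar step, or whether methyl is a special case. They also leave open whether the same methyl would lower the number when chloro replaces the bromo group.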